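Amino for Trifluoromethyl: What Compound 4 Might Dissolve To

The source may hold more compounds than are shown below. What is called first, only, known or untested is meant among the compounds shown, and "the series" means these compounds.

Compound 3, `CS(=O)(=O)c1ccc(-c2cnc3ccc(-c4cncc(C(F)(F)F)c4)nn23)cc1`, stands at a limit in a physicochemical assay for solubility, at pH 2; a higher number here means a more soluble compound, a lower number a less soluble compound: compound 3 gives < 5000 nM, which is a limit of the assay and not a number. Compound 1, `CS(=O)(=O)c1ccc(-c2cnc3ccc(-c4cncc(S(C)(=O)=O)c4)nn23)cc1`, also rests at a limit, giving < 5000 nM in this assay. Compound 2, `CS(=O)(=O)c1ccc(-c2cnc3ccc(-c4cccc(C(=O)NCCO)c4)nn23)cc1`, gives > 200000 nM in this assay, again a limit rather than a number. For the measured compounds named here, the one step between measured compounds, a step that the two limits leave unreadable from compound 1 to compound 3, cannot be read from the two limits. Compound 4, `CS(=O)(=O)c1ccc(-c2cnc3ccc(-c4cncc(N)c4)nn23)cc1`, differs from compound 3 by amino in place of trifluoromethyl on an aromatic carbon. Going by the values given here, no measured step involves an amino group, so the size and direction of this step in this assay rest on nothing measured. Compound 4 is therefore estimated at 15000 nM, within 4000 nM to 80000 nM. The expected step is an at least 3.0-fold higher number from compound 3 to compound 4 (0.47 log units; beyond the scatter), held loosely.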

Compound 4, solubility: 174000 nM
For compound 4 the middle estimate is 12-fold (1.06 log units) below the measured one, and the stated range ends below it.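

For the compounds shown here, at this position, on a six-membered aromatic ring with 1 nitrogen, amino in place of trifluoromethyl gives the first readable step in this assay: an at least 34-fold higher number from compound 3 to compound 4 (1.54 log units; beyond the scatter). Amino in place of methylsulfonyl at the same position also gives a readable step: an at least 34-fold higher number from compound 1 to compound 4 (1.54 log units; beyond the scatter). Both steps start from a limit and not from a number: the limit of < 5000 nM in this assay, at which 2 of the 4 values shown sit.

As far as these compounds go, whether a methylamino group or a carboxylic acid at this position would give a step of similar size remains open. The compounds shown also leave open how far the size of these steps depends on the ring nitrogen.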